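Nitro to methyl on the shared core

The compounds below may be only part of what the source reports. "The series", "measured", "known", "first", "only" and "open" are said of these compounds alone.

Measured in a functional assay on MCF7 cells (Homo sapiens) for inhibition, with a stated time of 48 h; on this read-out higher numbers stand for weaker inhibition and lower numbers for stronger inhibition
- compound 1 `COc1cc(Sc2c[nH]c3ccccc23)cc(OC)c1OC` gives 34 nM
- compound 2 `COc1cc(Sc2c[nH]c3ccc([N+](=O)[O-])cc23)cc(OC)c1OC` gives 560 nM

Compound 2 holds the higher of the two numbers. Compound 3 (`COc1cc(Sc2c[nH]c3ccc(C)cc23)cc(OC)c1OC`) replaces the nitro of compound 2 with methyl on the same aromatic carbon (methyl in place of nitro on an aromatic carbon). Going by the values given here, the one measured step that bears on this is large and beyond the scatter (a 16-fold higher number from compound 1 to compound 2 (1.22 log units; beyond the scatter)), with nitro taking the place of hydrogen on an aromatic carbon. Methyl itself is unmeasured, so a sizeable step to a lower number in this assay is expected, probably short of a full return. The step expected is a 7.0-fold lower number from compound 2 to compound 3 (0.85 log units; beyond the scatter) by this estimate. Compound 3 is estimated at 80 nM with an expected range from 25 nM to 300 nM in this series.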

Compound 3, half-maximal inhibitory concentration: 16 nM
Estimate against measurement, compound 3: 5.0-fold (0.70 log units) above; the measured number lies below the stated range.
By their numbers in this assay, from the lowest: compound 3; then compound 1; then compound 2.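

In this assay methyl on this aromatic carbon gives a 2.1-fold lower number from compound 1 to compound 3 (0.33 log units; beyond the scatter) and so shows that the position takes a substituent with no loss against hydrogen, unlike nitro. Exchanging the two groups gives a 35-fold lower number from compound 2 to compound 3 (1.54 log units; beyond the scatter) as a large step, so the group at this carbon strongly sets the read-out on the shared core. No available data account for the split between nitro and methyl.

On these data alone, whether an amine or a chlorine atom here would track methyl or nitro stays open. So does whether a longer chain such as ethyl would hold the gain seen with methyl.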